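Chloro in place of (2-(dimethylamino)ethyl)amino in compound 3

The source may hold more compounds than are shown below. What is called first, only, known or untested is meant among the compounds shown, and "the series" means these compounds.

- compound 1 `CN(C)CCNc1ccnc2cc(OCc3ccc(F)cc3)ccc12` with 370 nM 
- compound 2 `C=CCOc1ccc2c(NCCN(C)C)ccnc2c1` with 860 nM 

Both were tested in a functional assay on HCT-116 cells (Homo sapiens) for cytotoxicity, read by MTT assay, with a stated time of 48 h (a lower number here means a stronger inhibitor, a higher number a weaker inhibitor), and compound 2 holds the higher number of the pair. For the measured compounds named here, the only measured step is a 2.3-fold higher number from compound 1 to compound 2 (0.37 log units; beyond the scatter) and it is modest, though beyond the usual scatter. That step concerns the group on the oxygen, not the part of the molecule now in question.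

Compound 3 `C=CCOc1ccc2c(Cl)ccnc2c1` differs from compound 2 as follows: chloro in place of (2-(dimethylamino)ethyl)amino on an aromatic carbon with chloro in place of (2-(dimethylamino)ethyl)amino on an aromatic carbon, opposite the ring nitrogen. Going by the values given here, no measured step touches this place. Compound 1 at 370 nM and compound 2 at 860 nM both carry the (2-(dimethylamino)ethyl)amino group, so the data do not yet show how a compound without it behaves. Even so, removing the whole group is expected to weigh more than the modest step already seen, in the direction of a weaker inhibitor. A much higher number is expected, an estimated 17-fold higher number from compound 2 to compound 3 (1.24 log units; beyond the scatter) for this change. Compound 3 is estimated at 15000 nM within an expected range from 4000 nM to 60000 nM in this reading.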

Compound 3, half-maximal inhibitory concentration: 2570 nM
For compound 3 the middle estimate is 5.8-fold (0.77 log units) above the measured one; measured number outside the range, below it.
By their numbers in this assay, from the lowest: compound 1; then compound 2; then compound 3.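

In this assay, for the compounds shown here, the only measured change at the aromatic carbon opposite the ring nitrogen gives a 3.0-fold higher number from compound 2 to compound 3 (0.48 log units; beyond the scatter). Exchanging the whole (2-(dimethylamino)ethyl)amino group for a single chloro is thus a modest step in this pair, carrying the same rating as the step at the group on the oxygen, and compound 3 still has a measured value of 2570 nM in this cytotoxicity read-out, so on this allyloxy-bearing core the full side chain is not needed for a measurable effect. Nothing available here bears on why this exchange shifts the number by this amount.

The compounds shown leave open which part of the departing group accounts for the step, as a plain amine, a methylamino group or a longer chain such as (3-(dimethylamino)propyl)amino at this same place could each separate the contribution of the terminal dimethylamino nitrogen from that of the chain. They also leave open whether chloro at this place would give a step of similar size on the core of compound 1, which carries the 4-fluorophenyl group.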